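Swapping Methoxy for Amino on the Nitrile Analogue

The source may hold more compounds than are shown below. What is called first, only, known or untested is meant among the compounds shown, and "the series" means these compounds.

Compound 1 `COc1ccnc(Nc2ccc(Cl)c(OCC=C(C)C)c2)n1` is the starting point. In an ADME assay on MT2 cells (Homo sapiens) for cytotoxicity (on this read-out higher numbers stand for lower toxicity in this test and lower numbers for higher toxicity in this test), compound 1 gives 9000 nM. Compound 2 `CC(C)=CCOc1cc(Nc2nccc(N)n2)ccc1Cl` differs from compound 1 by amino in place of methoxy on an aromatic carbon. In this assay compound 2 gives 500 nM, a step of an 18-fold lower number from compound 1 to compound 2 (1.26 log units; beyond the scatter). Compound 3 `COc1ccnc(Nc2ccc(C#N)c(OCC=C(C)C)c2)n1` differs from compound 1 in its core by cyano in place of chloro on an aromatic carbon. In this assay compound 3 gives 230 nM, the lowest of the three, a step of a 39-fold lower number from compound 1 to compound 3 (1.59 log units; beyond the scatter). Compound 4 `CC(C)=CCOc1cc(Nc2nccc(N)n2)ccc1C#N` has not yet been measured. It differs from compound 3 by amino in place of methoxy on an aromatic carbon, the same change, at a place described in the same words, as that from compound 1 to compound 2. A step in the same direction is expected from compound 3 to compound 4, estimated as a 5.8-fold lower number from compound 3 to compound 4 (0.76 log units; beyond the scatter), resting on the large step of an 18-fold lower number from compound 1 to compound 2 (1.26 log units; beyond the scatter). Compound 4 is therefore expected to give about 40 nM, likely between 8 nM and 200 nM.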

Compound 4, half-maximal cytotoxic concentration: 41 nM
Compound 4: the middle estimate sits 1.0-fold (0.01 log units) below what was measured; the measured number falls inside the stated range.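

Amino in place of methoxy gives a 5.6-fold lower number from compound 3 to compound 4 (0.75 log units; beyond the scatter) in the same direction as before but of a different size: the same change on two cores in this assay, an 18-fold lower number (1.26 log units; beyond the scatter) from compound 1 to compound 2 and a 5.6-fold lower number (0.75 log units; beyond the scatter) from compound 3 to compound 4, 3.2-fold (0.51 log units) apart, beyond the scatter of two such steps. Cyano in place of chloro gives a 12-fold lower number from compound 2 to compound 4 (1.09 log units; beyond the scatter) with the same outcome: the same change on two cores in this assay, a 39-fold lower number (1.59 log units; beyond the scatter) from compound 1 to compound 3 and a 12-fold lower number (1.09 log units; beyond the scatter) from compound 2 to compound 4, 3.2-fold (0.51 log units) apart, beyond the scatter of two such steps. Each change thus keeps its direction on both cores, yet the size of a step on one core does not carry over unchanged to the other, and two pairs cannot show how either change would behave on any further core.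

Still open, as far as these compounds go, is how a methylamino group or a hydroxyl group would read at the place of the amino group. Also open, from the compounds shown here alone, is whether a trifluoromethyl group in place of the nitrile would move the number the same way.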